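A New Group on the Sulfonyl Sulfur of Compound 2

A few compounds are considered here, and "the series" means these few. Any claim that something is new, unique, unknown or untested is made for them only; others in the source may bear on it.

Compound 1 `CCn1c([C@@H](C)NS(=O)(=O)c2ccc(C)cc2)nc2ccc(C(F)(F)F)cc21`: > 100 mL.min-1.g-1 (a limit of the assay)
Compound 2 `CCn1c([C@@H](C)NS(=O)(=O)c2cnc(C)n2C)nc2ccc(C(F)(F)F)cc21`: 58 mL.min-1.g-1

Among the compounds with values here, in an ADME assay (liver) for metabolic stability, with Liver microsome (Homo sapiens) as the target, read by LC-MS, using microsomes and NADPH, with a stated time of 5 min, at 37 degrees C (a higher number here means faster removal of the compound, a lower number slower removal), compound 2 gives 58 mL.min-1.g-1 as the only true number so far. Compound 1 reads > 100 mL.min-1.g-1 and that is a limit, not a number.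

Compound 3 `CCn1c([C@@H](C)NS(=O)(=O)c2cnc(NC(C)=O)s2)nc2ccc(C(F)(F)F)cc21` carries 2-acetamido-1,3-thiazol-5-yl in place of 1,2-dimethyl-1H-imidazol-5-yl on a sulfonyl sulfur and otherwise matches compound 2. Within the data shown here, one measured step bears on this place: an at least 1.7-fold lower number from compound 1 to compound 2 (0.23 log units; that floor lies within the scatter) and it brought in 1,2-dimethyl-1H-imidazol-5-yl in place of 4-methylphenyl. That step starts from a limit, and its floor lies within the scatter, so it offers only a weak guide to size and none to the new group. With compound 2 at 58 mL.min-1.g-1 as the anchor, no step beyond the scatter is expected in this assay and neither direction is favoured. The expected step of a 1.1-fold lower number from compound 2 to compound 3 (0.02 log units; within the scatter) is an estimate that stays within the usual scatter. For compound 3 the estimated value is 55 mL.min-1.g-1 with an expected range from 22 mL.min-1.g-1 to 120 mL.min-1.g-1 in this estimate.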

Compound 3, intrinsic clearance in microsomes: 15 mL.min-1.g-1
Estimate against measurement, compound 3: 3.7-fold (0.56 log units) above; measured number outside the range, below it.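

With 2-acetamido-1,3-thiazol-5-yl in place of 1,2-dimethyl-1H-imidazol-5-yl on the sulfonyl sulfur, this assay gives a 3.9-fold lower number from compound 2 to compound 3 (0.59 log units; beyond the scatter), so a change at this place alone now clearly exceeds the scatter. Measured against 4-methylphenyl, the same group gives an at least 6.6-fold lower number from compound 1 to compound 3 (0.82 log units; beyond the scatter), and this size is only a floor because the starting value is a limit: the limit of > 100 mL.min-1.g-1 in this assay, at which 1 of the 3 values shown sits. Both groups that differ between compound 2 and compound 3 are five-membered aromatic rings with 2 hetero atoms, so the lower number goes with a change in the make-up and substituents of the ring, not with a change in ring size or ring count.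

The swap changes the ring and adds the acetamido group in one move, so the compounds shown cannot tell which of the two goes with the lower number. A plain 1,3-thiazol-5-yl group, or a 2-amino-1,3-thiazol-5-yl group with a free amine in place of the acetamido group, would pull these two parts apart.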